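Trading 2-Carboxyethenyl for 2-(Methoxycarbonyl)ethyl

This account rests on a few compounds, and the source may have more. Where it says the series, first, only, none or still open, it means among the compounds named here.

Three compounds sharing one core have been examined in an assay on a protein complex for inhibition of CDK8/Cyclin C (Homo sapiens), with a stated time of 1 h, tested at 10 uM; a higher number here means more inhibition at the concentration tested (going by the name of the read-out), a lower number less inhibition. Compound 1 `NC(=O)/C=C/c1ccncc1-c1ccc2ccccc2c1` gives 102%, compound 2 `CNC(=O)/C=C/c1ccncc1-c1ccc2ccccc2c1` gives 101%, and compound 3 `O=C(O)/C=C/c1ccncc1-c1ccc2ccccc2c1` gives 102%. Compound 3 stands level with compound 1, the two together being the highest of the three numbers; its nearest neighbour is compound 1 with no change at the digits printed from compound 1 to compound 3 (within the scatter), and its furthest is compound 2 with a number 1 percentage points higher from compound 2 to compound 3 (within the scatter). The step of a number 1 percentage points lower from compound 1 to compound 2 (within the scatter) completes the picture: every exchange made so far on the carbonyl carbon has left the read-out at its ceiling.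

Compound 4 `COC(=O)CCc1ccncc1-c1ccc2ccccc2c1` has not yet been measured. 2-(methoxycarbonyl)ethyl in place of 2-carboxyethenyl on an aromatic carbon The measured steps bear on this change only in part. They show that exchanging amino, methylamino and hydroxy on the carbonyl carbon leaves the number unchanged within the scatter, but none of them removes a double bond outside aromatic rings, and none introduces a 2-(methoxycarbonyl)ethyl group. With all three measured values at the ceiling of this assay, any cost of the new change can only show as a drop. Compound 4 is therefore expected to give 80%, with a range from 40% to 102%, which means an estimated step of a number 22 percentage points lower from compound 3 to compound 4 (beyond the scatter).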

Compound 4, a percentage reported as inhibition, at one concentration (the size of the read-out at that concentration, not a potency): 98%
Compound 4: the middle estimate sits 18 percentage points below what was measured, within the range that was stated.
By their numbers in this assay, from the lowest: compounds 4, 2, 1 and 3 (each within the scatter of the next).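

In this assay, the exchange of 2-carboxyethenyl for 2-(methoxycarbonyl)ethyl on the aromatic carbon opposite the ring nitrogen gives a number 4 percentage points lower from compound 3 to compound 4 (within the scatter) and so leaves the read-out in place, even though the side chain goes from 2 double bonds outside aromatic rings to 1 and from 1 hydrogen-bond donor to 0. For the compounds shown here, the comparisons with the two amides agree, with a number 3 percentage points lower from compound 2 to compound 4 (within the scatter) and a number 4 percentage points lower from compound 1 to compound 4 (within the scatter), which extends what the earlier compounds showed: there only the group on the carbonyl carbon varied, whereas here the chain linking that carbonyl to the aromatic ring changes as well and the number still stays within the scatter. Nothing available explains why this position accepts the exchange.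

All four compounds sit close to the top of the read-out at a single concentration, so any differences in potency among them remain hidden. Going by these compounds, whether this position would accept a saturated chain ending in a carboxylic acid, a longer chain or a terminal amine also stays open.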